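This account rests on a few compounds, and the source may have more. Where it says the series, first, only, none or still open, it means among the compounds named here.

Measured so far:
- Compound 1 `Cn1cc(-c2cnc3ccnc(N)c3c2)cn1` gives 33400 nM
- Compound 2 `Cn1cc(-c2cnc3ccc(NS(=O)(=O)c4ccc(Cl)cc4Cl)nc3c2)cn1` gives > 50000 nM (a limit of the assay, not a number)

For the measured compounds named here, in a functional assay on A549 cells (Homo sapiens) for antiproliferative activity, read by MTT assay, with a stated time of 48 h (a higher number here means a weaker inhibitor, a lower number a stronger inhibitor), compound 1 gives 33400 nM, the only actual number so far. Compound 3 `CCNc1nccc2ncc(-c3cnn(C)c3)cc12` turns the amino of compound 1 into ethylamino, with this difference: ethyl in place of hydrogen on a nitrogen on an aromatic ring. Going by the values given here, no measured step covers this change, so no shift beyond the scatter is expected in this assay, in either direction. The expected step runs a 1.1-fold lower number from compound 1 to compound 3 (0.05 log units; within the scatter). For compound 3 the estimated value is 30000 nM, with an expected range from 12000 nM to 50000 nM.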

Compound 3, half-maximal inhibitory concentration: 40700 nM
The estimate for compound 3 lay 1.4-fold (0.13 log units) below the measured number; measured number inside the range.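

In this assay, ethyl in place of hydrogen on a nitrogen on an aromatic ring gives a 1.2-fold higher number from compound 1 to compound 3 (0.09 log units; within the scatter), so this nitrogen carries ethyl with no shift beyond the scatter. For the compounds shown here, this is the first reading of any change at this position, and it is a single step. Compound 2 stands at a limit of the assay, not a number, so little room shows on the weak side: the limit of > 50000 nM in this assay, at which 1 of the 3 values shown sits.

On these data alone, whether a longer chain, a benzyl group or a morpholine ring on this nitrogen would move the number beyond the scatter stays open.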